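Rearranging the Fluorines on the Terminal Ring

The source may hold more compounds than are shown below. What is called first, only, known or untested is meant among the compounds shown, and "the series" means these compounds.

Of the compounds shown here, three sharing one core have been measured in a functional assay on HEK293 cells for antagonist activity at cysteinyl leukotriene receptor 2 (Homo sapiens), read by fluorescence and calcium flux, with stated times of 30 min and 1 h; on this read-out lower numbers stand for stronger inhibition and higher numbers for weaker inhibition. Compound 1 `Cc1c(CCCC(=O)O)c2cccc(/C=C/c3ccc(OCCCCc4ccccc4)cc3)c2n1CC(=O)O` gives 4.7 nM. Compound 2 `Cc1c(CCCC(=O)O)c2cccc(/C=C/c3ccc(OCCCCc4c(F)cc(F)c(F)c4F)cc3)c2n1CC(=O)O` carries 2,3,4,6-tetrafluorophenyl where compound 1 carries phenyl; in this assay compound 2 gives 2.2 nM. Compound 3 `Cc1c(Cl)cccc1CCCCOc1ccc(C#Cc2cccc3c(CCCC(=O)O)c(C)n(CC(=O)O)c23)cc1` gives 0.88 nM. Among these three numbers compound 2 stands second highest; its nearest neighbour is compound 1, with the higher number, and its furthest is compound 3, with the lower number.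

Among the measured compounds shown here, the only measured step touching the same part of the molecule is a 2.1-fold lower number from compound 1 to compound 2 (0.33 log units; beyond the scatter). Compound 4 `Cc1c(CCCC(=O)O)c2cccc(/C=C/c3ccc(OCCCCc4cc(F)c(F)c(F)c4F)cc3)c2n1CC(=O)O` has not yet been measured. It differs from compound 2 only in how the fluorines are arranged on that ring: 2,3,4,5-tetrafluorophenyl in place of 2,3,4,6-tetrafluorophenyl on a saturated chain carbon, four bonds along the chain from an oxygen on an aromatic ring. For the measured compounds named here, no measured pair shows what such a rearrangement alone does; the step from compound 1 to compound 2 shows only that replacing phenyl with a tetrafluorophenyl shifted the number modestly. Keeping the same fluorines but placing them differently is therefore expected to move the number in this assay by no more than that, and most likely the step of a 1.1-fold higher number from compound 2 to compound 4 (0.06 log units; within the scatter) is expected to stay within the scatter. Compound 4 is expected to give 2.5 nM, within the range 1 nM to 6 nM.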

Compound 4, half-maximal inhibitory concentration: 1.5 nM
Compound 4: middle estimate off by 1.7-fold (0.22 log units), on the high side; low and high end bracket the measured number.
By their numbers in this assay, from the lowest: compounds 3, 4 and 2 (each within the scatter of the next, the first and the last beyond it); then compound 1.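

In this assay, the first measured rearrangement of the same four fluorines, from 2,3,4,6-tetrafluorophenyl to 2,3,4,5-tetrafluorophenyl, gives a 1.5-fold lower number from compound 2 to compound 4 (0.17 log units; within the scatter), so at this position the two arrangements cannot be told apart. Compared with the plain phenyl, both arrangements lie beyond the scatter, with a 2.1-fold lower number from compound 1 to compound 2 (0.33 log units; beyond the scatter) and a 3.1-fold lower number from compound 1 to compound 4 (0.50 log units; beyond the scatter), so across these three compounds the lower number does not depend on which of the two fluorine patterns the ring carries. No supporting measurement is available to explain why these numbers fall as they do.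

The compounds shown leave open how many fluorines the ring needs, and whether a monofluorophenyl or a pentafluorophenyl on the same saturated chain carbon would give a number closer to the tetrafluorophenyl compounds or to the phenyl of compound 1. They also leave open whether a longer chain carrying the 2,3,4,5-tetrafluorophenyl ring would keep the number of compound 4 at 1.5 nM, or lose what the fluorines appear to add.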